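The compounds below may be only part of what the source reports. "The series", "measured", "known", "first", "only" and "open" are said of these compounds alone.

Working notes on the urea series. Compound 1 `CNC(=O)C#Cc1ccc(NC(=O)Nc2ccc(Cl)c(C(F)(F)F)c2)cc1` carries the shared core of the set. In a functional assay on A-375 cells (Homo sapiens) for inhibition, read by MTT assay, with a stated time of 120 h (on this read-out lower numbers stand for stronger inhibition and higher numbers for weaker inhibition), compound 1 reaches only a limit, > 50000 nM. Compound 2 `CNC(=O)/C(C)=C/c1ccc(NC(=O)Nc2ccc(Cl)c(C(F)(F)F)c2)cc1` likewise gives only a limit, > 50000 nM. Among the measured compounds shown here, compound 3 `O=C(/C=C/c1ccc(NC(=O)Nc2ccc(Cl)c(C(F)(F)F)c2)cc1)NC1CCC1` gives 15400 nM, the sole number in the set, the other two values sitting at the limit of > 50000 nM in this assay, at which 2 of the 3 values shown sit. The readable steps are an at least 3.2-fold lower number from compound 1 to compound 3 (0.51 log units; beyond the scatter) and an at least 3.2-fold lower number from compound 2 to compound 3 (0.51 log units; beyond the scatter), each changing the amide and the linker together. Compound 4 `CC1CN(C(=O)/C=C/c2ccc(NC(=O)Nc3ccc(Cl)c(C(F)(F)F)c3)cc2)CC(C)O1` carries 2,6-dimethylmorpholin-4-yl in place of cyclobutylamino on a carbonyl carbon. For the measured compounds named here, no measured step alters the amide nitrogen substituent alone, so none bears directly on it; a step within the scatter in this assay is expected, direction uncertain. Compound 4 is estimated at 20000 nM (range 6000 nM to 60000 nM), meaning an expected step of a 1.3-fold higher number from compound 3 to compound 4 (0.11 log units; within the scatter).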

Compound 4, half-maximal inhibitory concentration: > 50000 nM
Compound 4: a limit, no number (the forecaster's own chance of this, stated with the estimate: 30%); middle value at least 2.5-fold (0.39 log units) from the limit.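

Among the compounds shown here, this is the first step confined to the amide nitrogen substituent: in this assay, 2,6-dimethylmorpholin-4-yl in place of cyclobutylamino on a carbonyl carbon gives an at least 3.2-fold higher number from compound 3 to compound 4 (0.51 log units; beyond the scatter). Compound 4 stands at a limit, not a number, and the entering group has no hydrogen-bond donor where cyclobutylamino has one. Compound 3 remains the only compound with a number: the limit of > 50000 nM in this assay, at which 3 of the 4 values shown sit.

Going by these compounds, whether the ring or the amide hydrogen carries the step stays open, as cyclopentylamino or unsubstituted morpholin-4-yl would be needed to separate them. The step from compound 1 to compound 2 cannot be read.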